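A few compounds are considered here, and "the series" means these few. Any claim that something is new, unique, unknown or untested is made for them only; others in the source may bear on it.

Measured compounds:
Compound 1, `COc1cc(-c2cc(/C=C/C(=O)c3ccc(N)cc3)[nH]n2)cc(OC)c1OC`: in a functional assay on UO-31 cells (Homo sapiens) for inhibition, read by sulforhodamine B assay, with a stated time of 48 h (a higher number here means a weaker inhibitor of growth, a lower number a stronger inhibitor of growth), compound 1 gives 2860 nM.
Compound 2, `COc1ccc(C(=O)/C=C/c2cc(-c3cc(OC)c(OC)c(OC)c3)n[nH]2)cc1OC`: in this assay compound 2 gives 2570 nM.

Compound 2 holds the lower of the two numbers, but the step of a 1.1-fold lower number from compound 1 to compound 2 (0.05 log units; within the scatter) lies within the scatter, so the two are not separated. Compound 3, `COc1ccc(C(=O)/C=C/c2cc(-c3cc(OC)c(OC)c(OC)c3)n[nH]2)cc1`, differs from compound 2 by hydrogen in place of methoxy on an aromatic carbon. Within the data shown here, only the step of a 1.1-fold lower number from compound 1 to compound 2 (0.05 log units; within the scatter) bears on this change, and it altered the same aryl group on the carbonyl without moving the number beyond the scatter. For compound 3 no step beyond the scatter is therefore expected, a 1.1-fold higher number from compound 2 to compound 3 (0.02 log units; within the scatter), with an estimate of 2700 nM and a range from 1200 nM to 6000 nM.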

Compound 3, concentration for total growth inhibition: 2840 nM
For compound 3 the middle estimate is 1.1-fold (0.02 log units) below the measured one; measured number inside the range.
By their numbers in this assay, from the lowest: compounds 2, 3 and 1 (each within the scatter of the next).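

With 4-methoxyphenyl in place of 3,4-dimethoxyphenyl on the carbonyl, the result is a 1.1-fold higher number from compound 2 to compound 3 (0.04 log units; within the scatter), so in this assay this methoxy, ortho to a methoxy group, can be replaced by hydrogen without a step beyond the scatter. Methoxy in place of amino on the same aromatic ring gives a 1.0-fold lower number from compound 1 to compound 3 (0.00 log units; within the scatter), so these two groups are not separated either. Nothing available explains why these numbers stay together. From the compounds shown here alone, whether a carboxylic acid or a longer chain on this ring would move the number beyond the scatter remains open, as does the effect of an unsubstituted phenyl there.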